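The source may hold more compounds than are shown below. What is called first, only, known or untested is meant among the compounds shown, and "the series" means these compounds.

Two compounds of the series carry numbers in an assay on CHO cells for agonist activity at Free fatty acid receptor 1 (Homo sapiens), read by luminescence, with a stated time of 20 s, in the presence of a further agent that is not named here; on this read-out lower numbers stand for an effect already at smaller amounts and higher numbers for an effect only at larger amounts of compound. Compound 1 `Cc1ccccc1-c1cccc(COc2ccc([C@H](CC(=O)O)c3nccn3C)cc2)c1` gives 43 nM, and compound 2 `Cn1ccnc1[C@@H](CC(=O)O)c1ccc(OCc2cccc(-c3ccccc3S(C)(=O)=O)c2)cc1` gives 23000 nM. Among the compounds with values here, compound 2 therefore stands at the higher of the two numbers, the only measured step being a 530-fold higher number from compound 1 to compound 2 (2.73 log units; beyond the scatter). Compound 3 `Cc1c(Cl)cccc1-c1cccc(COc2ccc([C@H](CC(=O)O)c3nccn3C)cc2)c1` is not yet measured in this assay. It differs from compound 2 by 3-chloro-2-methylphenyl in place of 2-(methylsulfonyl)phenyl on an aromatic carbon. The change from compound 2 to compound 3 thus removes the methylsulfonyl group that had entered between compound 1 and compound 2 and restores the methyl, while a chlorine is added to the same phenyl; compound 3 can be read as compound 1 carrying one additional chlorine. Within the data shown here, the only measured step that bears on this is a 530-fold higher number from compound 1 to compound 2 (2.73 log units; beyond the scatter), a large one. Undoing that change is expected to give a step of comparable size in the opposite direction, so compound 3 is expected to land near compound 1, the chlorine being the only part without a measured precedent, hence a 580-fold lower number from compound 2 to compound 3 (2.76 log units; beyond the scatter). Compound 3 is estimated at 40 nM, with a range of 10 nM to 200 nM.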

Compound 3, half-maximal effective concentration: 61 nM
Compound 3: the middle estimate sits 1.5-fold (0.18 log units) below what was measured; the range from low to high includes it.
By their numbers in this assay, from the lowest: compounds 1 and 3 (each within the scatter of the next); then compound 2.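

In this assay, 3-chloro-2-methylphenyl in place of 2-(methylsulfonyl)phenyl on this aromatic carbon gives a 380-fold lower number from compound 2 to compound 3 (2.58 log units; beyond the scatter), so a large step of the size seen on entering methylsulfonyl also appears when that group leaves and the methyl returns with a chlorine. Chloro in place of hydrogen on the methylphenyl gives a 1.4-fold higher number from compound 1 to compound 3 (0.15 log units; within the scatter), so this added chlorine brings no step that can be told from the scatter, and compounds 1 and 3 stand together, apart from compound 2. Among the three compounds, the methylsulfonyl group is thus the only change at this place that carries a large step, while the 3-chloro-2-methylphenyl group keeps the number of compound 3 within the scatter of compound 1.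

The compounds shown leave open whether the large step belongs to methylsulfonyl specifically or would also follow from another group at that position on the phenyl, such as a methoxy, an amine or a carboxylic acid. They also leave open whether chlorine at other ring positions, or a fluorine or a trifluoromethyl in its stead, would stay as close to compound 1, and no measurement given here accounts for any of these steps.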